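The compounds below may be only part of what the source reports. "The series", "measured", "known", "first", "only" and "open" are said of these compounds alone.

Measured compounds:
- compound 1 `O=C(NOCc1ccccc1Cl)c1cn(-c2ccccc2)nc1-c1ccccc1` gives 82100 nM in an ADME assay on HEK-293T cells (Homo sapiens) for antiproliferative activity, read by MTT assay, with a stated time of 48 h, in the presence of a further agent that is not named here; a higher number here means that more compound is tolerated, a lower number that less compound is tolerated
- compound 2 `COc1ccc(-c2nn(-c3ccccc3)cc2C(=O)NOCc2ccccc2)cc1` gives 201000 nM in this assay
- compound 3 `COc1ccc(-c2nn(-c3ccccc3)cc2C(=O)NOCc2ccccc2F)cc1` gives 24600 nM in this assay

Compound 3 stands lowest of the three, beyond the scatter against compound 1 and against compound 2. Among the compounds with values here, the one single-point step here is an 8.2-fold lower number from compound 2 to compound 3 (0.91 log units; beyond the scatter). Compound 4 `COc1ccc(-c2nn(-c3ccccc3)cc2C(=O)NOCc2ccccc2Cl)cc1` differs from compound 3 by chloro in place of fluoro on an aromatic carbon. Within the data shown here, no measured pair shows that change alone; compound 1, which carries the chloro but lacks the methoxy, gives 82100 nM in this assay, a higher number than compound 3. A modest step upward is therefore expected, a 1.6-fold higher number from compound 3 to compound 4 (0.21 log units; within the scatter), with wide uncertainty. Compound 4 is estimated at 40000 nM in this assay, range 12000 nM to 130000 nM.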

Compound 4, half-maximal cytotoxic concentration: 586000 nM
Compound 4: the middle estimate sits 15-fold (1.17 log units) below what was measured; measured number above the stated range.
By their numbers in this assay, from the lowest: compound 3; then compound 1; then compound 2; then compound 4.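

In this assay, within the data shown here, the choice of halogen on this aromatic carbon carries more weight than the earlier compounds showed, with a 24-fold higher number from compound 3 to compound 4 (1.38 log units; beyond the scatter) in the series. Fluoro and chloro also part in direction from hydrogen, as chloro gives a 2.9-fold higher number from compound 2 to compound 4 (0.46 log units; beyond the scatter) against the fall seen with fluoro. With chloro held fixed, methoxy in place of hydrogen gives a 7.1-fold higher number from compound 1 to compound 4 (0.85 log units; beyond the scatter) in the same upward direction. As far as these compounds go, whether methoxy does the same alongside fluoro or hydrogen stays open, as does the reading of bromo or methyl on this carbon. No evidence on the cause of these steps is at hand.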